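The compounds below may be only part of what the source reports. "The series", "measured", "known", "first", "only" and "open" are said of these compounds alone.

Of the compounds shown here, three have so far been measured in an in vivo ADME assay on the whole organism for metabolic stability, with Mus musculus as the target, read by LC-MS, at a dose of 160 mg/kg by the oral route; on this read-out lower numbers stand for a shorter-lived compound and higher numbers for a longer-lived compound. Compound 1 `CC(C)(C)OC(=O)/N=C(\NC1=NC(=O)CN1C(C)(C)C)Nc1ccc(Cl)c(Cl)c1` gives a value that is only a limit of the assay, < 0.167 h, which is the limit of < 0.167 h in this assay, at which 1 of the 3 values shown sits. Compound 2 `CC(C)N1CC(=O)N=C1N/C(=N\C(C)(C)C)Nc1ccc(Cl)c(Cl)c1` gives 0.0287 h in this assay, the lowest of the two numbers shown. Compound 3 `CC(C)N1CC(=O)N=C1N/C(=N/c1ccc(Cl)c(Cl)c1)N1CCCCC1` gives 0.3 h, a higher number than compound 2 by a gap beyond the usual scatter. Compound 4 `CC(C)N1CC(=O)N=C1N/C(=N\C(=O)C(C)(C)C)Nc1ccc(Cl)c(Cl)c1` has not yet been measured. It differs from compound 2 in one place: (tert-butyl)carbonyl in place of tert-butyl on a double-bonded nitrogen. For the measured compounds named here, no measured pair of compounds shows this same change, so no measured step guides the expectation, and the structural change alone is the only basis. The expected step in this assay is therefore small, a 1.7-fold higher number from compound 2 to compound 4 (0.24 log units; within the scatter), and in either direction within the usual scatter. Compound 4 is expected to give 0.05 h, with a likely range from 0.015 h to 0.2 h.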

Compound 4, half-life: > 1 h
Compound 4 ended at the assay's limit (the forecaster's own chance of this, stated with the estimate: 25%); at least 20-fold (1.30 log units) between middle value and limit.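

In this assay, exchanging the tert-butyl on a double-bonded nitrogen for (tert-butyl)carbonyl gives an at least 34-fold higher number from compound 2 to compound 4 (1.54 log units; beyond the scatter). For the compounds shown here, this is the first single-place comparison, and it shows that a change at this one position can shift the half-life well beyond the scatter, although the group gains only a carbonyl. For compound 4, > 1 h is a limit of the assay and not a number: the limit of > 1 h in this assay, at which 1 of the 4 values shown sits.

This one pair cannot separate the part played by the carbonyl from that of the tert-butyl attached to it, a question that an acetyl or a benzoyl group on this nitrogen could help to answer. Going by these compounds, it also remains open whether the same change would have a similar effect on a different core.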